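The compounds below may be only part of what the source reports. "The series", "measured", "known", "first", "only" and "open" are said of these compounds alone.

Measured compounds in a functional assay on PC-3 cells (Homo sapiens) for cytotoxicity, read by MTT assay, with a stated time of 72 h; on this read-out higher numbers stand for weaker inhibition and lower numbers for stronger inhibition:

Compound 1, `O=C(Nc1ccc(Oc2ccnc3[nH]ccc23)cc1)c1nn(-c2ccc(Cl)cc2)ccc1=O`, gives 32400 nM.
Compound 2, `COc1ccc(-n2ccc(=O)c(C(=O)Nc3ccc(Oc4ccnc5[nH]ccc45)cc3)n2)cc1`, gives only a limit of the assay, > 60000 nM.
Compound 3, `Cn1ccc2c(Oc3ccc(NC(=O)c4nn(-c5ccc(Cl)cc5)ccc4=O)cc3)ccnc21`, gives only a limit of the assay, > 60000 nM.

Compound 3 therefore stands at the limit of this assay; a number rather than a limit is known only for compound 1. Two steps lead away from compound 1: an at least 1.8-fold higher number from compound 1 to compound 2 (0.26 log units; that floor lies within the scatter) and an at least 1.8-fold higher number from compound 1 to compound 3 (0.26 log units; that floor lies within the scatter). Both end at the limit of > 60000 nM in this assay, at which 2 of the 3 values shown sit, so the true size of neither step is known beyond its floor.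

Compound 4, `COc1ccc(-n2ccc(=O)c(C(=O)Nc3ccc(Oc4ccnc5c4ccn5C)cc3)n2)cc1`, differs from compound 3 by methoxy in place of chloro on an aromatic carbon. The same change has been measured once, where an at least 1.8-fold higher number from compound 1 to compound 2 (0.26 log units; that floor lies within the scatter) carried the number from a measured value up to the limit. Among the three measured compounds nothing shows methoxy in place of chloro giving a lower number in this assay. Compound 4 is therefore expected to show the step that the limit leaves unreadable from compound 3 to compound 4, that is, no stronger inhibition than the limit already indicates. The estimate for compound 4 in this assay is 100000 nM, within 40000 nM to 300000 nM, and most likely the assay again reports only a limit.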

Compound 4, half-maximal inhibitory concentration: > 60000 nM
Compound 4 ended at the assay's limit; the forecaster's own chance of this, stated with the estimate: 85%; the middle value does not contradict the limit.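

No new step can be read: compound 4, like compound 2 and compound 3, gives a limit rather than a number, so its steps from compound 2 and compound 3 stay unreadable: the limit of > 60000 nM in this assay, at which 3 of the 4 values shown sit.

The compounds shown leave open what true numbers lie behind that limit for compound 2, compound 3 and compound 4, and so whether the two changes together differ from either alone.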